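The source may hold more compounds than are shown below. What is called first, only, known or untested is meant among the compounds shown, and "the series" means these compounds.

Compound 1 `COc1nsnc1C(=O)Nc1cc(C(F)(F)F)cc(C(F)(F)F)c1`: in an assay on isolated protein for inhibition of mitogen-activated protein kinase kinase kinase 14 (Homo sapiens), read by ADP-Glo, with a stated time of 60 min, in the presence of a further agent that is not named here (on this read-out lower numbers stand for stronger inhibition and higher numbers for weaker inhibition), compound 1 gives > 100000 nM, a limit of the assay.
Compound 2 `O=C(Nc1cc(C(F)(F)F)cc(C(F)(F)F)c1)c1n[nH]nc1O`: in this assay compound 2 gives > 100000 nM, also a limit.
Compound 3 `Cn1cc(C(=O)Nc2cc(C(F)(F)F)cc(C(F)(F)F)c2)c(O)n1`: in this assay compound 3 gives > 100000 nM, again a limit.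

Compound 3 therefore stands at the limit, as do the two other measured compounds (the limit of > 100000 nM in this assay, at which 3 of the 3 values shown sit). The steps a step that the two limits leave unreadable from compound 1 to compound 3 and a step that the two limits leave unreadable from compound 2 to compound 3 are both unreadable; each runs between two limits, so no size or direction can be taken from them. Compound 4 `O=C(Nc1cc(C(F)(F)F)cc(C(F)(F)F)c1)c1nonc1O` differs from compound 3 by 4-hydroxy-1,2,5-oxadiazol-3-yl in place of 3-hydroxy-1-methyl-1H-pyrazol-4-yl on a carbonyl carbon. Every measured step that bears on such a ring swap is unreadable, so no shift beyond the scatter is expected in this assay, and the estimated step of a number no higher from compound 3 to compound 4 (the limit leaves the size open) means none. Compound 4 is estimated at 100000 nM, within 30000 nM to 300000 nM.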

Compound 4, half-maximal inhibitory concentration: > 100000 nM
Compound 4: only a limit was reported (the forecaster's own chance of this, stated with the estimate: 85%); the middle value sits exactly at the limit.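

All four compounds, compound 1, compound 2, compound 3 and compound 4, sit at a limit in this assay, so no step among them can be read: the limit of > 100000 nM in this assay, at which 4 of the 4 values shown sit.

The compounds shown leave open whether any of these five-membered rings inhibits differently from another.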